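This account rests on a few compounds, and the source may have more. Where it says the series, first, only, none or still open, it means among the compounds named here.

Measured compounds and their numbers in a functional assay (aorta) with Oryctolagus cuniculus as the target; on this read-out lower numbers stand for stronger inhibition and higher numbers for weaker inhibition:

Compound 1 `CO/C(O)=C1\C(C)=NC(C)=C(C(=O)OCCCN2C(=O)c3ccccc3S2(=O)=O)C1c1ccccc1[N+](=O)[O-]` gives 1.5 nM in this assay.
Compound 2 `CCO/C(O)=C1\C(C)=NC(C)=C(C(=O)OCCCN2C(=O)c3ccccc3S2(=O)=O)C1c1ccccc1[N+](=O)[O-]` gives 2.6 nM in this assay.
Compound 3 `CO/C(O)=C1\C(C)=NC(C)=C(C(=O)OCCCN2C(=O)c3ccccc3S2(=O)=O)C1c1ccccc1Cl` gives 1.8 nM in this assay.

Not yet measured is compound 4 `CCO/C(O)=C1\C(C)=NC(C)=C(C(=O)OCCCN2C(=O)c3ccccc3S2(=O)=O)C1c1ccccc1Cl`, which is to be tested in this assay.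

The three measured compounds share one core and differ at two places. Compound 1 and compound 2 differ by one change, (methyl in place of hydrogen on a saturated chain carbon bound to an oxygen on an unsaturated carbon), and the step that goes with it is a 1.7-fold higher number from compound 1 to compound 2 (0.24 log units; within the scatter). Compound 1 and compound 3 differ in the core, namely (chloro in place of nitro on an aromatic carbon), and the step there is a 1.2-fold higher number from compound 1 to compound 3 (0.08 log units; within the scatter). Both steps stay inside the usual scatter of this assay, so none of the three measured compounds can be set apart from the others.

Compound 4 relates to compound 3 as compound 2 relates to compound 1: the change is methyl in place of hydrogen on a saturated chain carbon bound to an oxygen on an unsaturated carbon, and the place line reads word for word as it does for the pair of compound 1 and compound 2, so this is the same change, now made on the core of compound 3. Among the measured compounds shown here, only one measured instance of this change exists, so the expectation for compound 4 rests on compound 1 and compound 2 alone, through a 1.7-fold higher number from compound 1 to compound 2 (0.24 log units; within the scatter). For compound 4 the step is expected to be a 1.7-fold higher number from compound 3 to compound 4 (0.24 log units; within the scatter), about the size of the earlier one. For the measured compounds named here, compound 4 is therefore estimated at 3.1 nM, with a range from 1.5 nM to 6.5 nM that reflects the scatter of this assay and the single precedent.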

Compound 4, half-maximal inhibitory concentration: 3.9 nM
Beside the measured number, compound 4's estimate is 1.3-fold (0.10 log units) below it, within the range that was stated.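

In this assay, methyl in place of hydrogen on a saturated chain carbon bound to an oxygen on an unsaturated carbon gives a 2.2-fold higher number from compound 3 to compound 4 (0.34 log units; beyond the scatter), and the step on the core of compound 3 cannot be told apart from the one on the core of compound 1: the same change on two cores in this assay, a 1.7-fold higher number (0.24 log units; within the scatter) from compound 1 to compound 2 and a 2.2-fold higher number (0.34 log units; beyond the scatter) from compound 3 to compound 4, 1.3-fold (0.10 log units) apart, within the scatter of two such steps. Chloro in place of nitro on an aromatic carbon, now made on the ethoxy compounds, gives a 1.5-fold higher number from compound 2 to compound 4 (0.18 log units; within the scatter), and this change also carries over without a difference that can be read: the same change on two cores in this assay, a 1.2-fold higher number (0.08 log units; within the scatter) from compound 1 to compound 3 and a 1.5-fold higher number (0.18 log units; within the scatter) from compound 2 to compound 4, 1.3-fold (0.10 log units) apart, within the scatter of two such steps. Among the compounds shown here, the two changes therefore behave as roughly independent within these four compounds, but each comparison rests on a single pair of steps, and only the step to compound 4 from compound 3 lies beyond the scatter, so no general size for methoxy to ethoxy follows, nor any rule for other cores.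

The compounds shown leave open whether the trend continues with a longer chain such as propoxy or butoxy, or holds when an amine takes the place of the alkoxy group. They also leave open whether the same steps appear with a nitrile or a fluoro group in place of chloro on the aromatic carbon, and in any read-out other than this assay.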